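The compounds below may be only part of what the source reports. "The series", "measured", "known", "first", "only" and "open" are said of these compounds alone.

Compound 1 `c1ccc(-c2cc(-c3ccsc3)cc(-c3ccccn3)n2)nc1` is the reference point of this small set. In a functional assay on A549 cells (Homo sapiens) for antiproliferative activity (on this read-out higher numbers stand for weaker inhibition of growth and lower numbers for stronger inhibition of growth), compound 1 gives 0.62 ug/mL, the lowest of the two numbers shown. Compound 2 `c1ccc(-c2cc(-c3cccs3)cc(-c3ccncc3)n2)nc1` gives 36.2 ug/mL in this assay. Compound 3 `c1ccc(-c2cc(-c3ccsc3)cc(-c3cccnc3)n2)nc1` reaches only > 100 ug/mL, which is a limit of the assay rather than a number (the limit of > 100 ug/mL in this assay, at which 1 of the 3 values shown sits). Among the measured compounds shown here, the single step measured in one place, an at least 160-fold higher number from compound 1 to compound 3 (2.20 log units; beyond the scatter), is large and concerns an exchange of pyridin-2-yl for pyridin-3-yl.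

Compound 4 `c1ccc(-c2cc(-c3ccoc3)cc(-c3ccccn3)n2)nc1` differs from compound 1 at another place: furan-3-yl in place of thiophen-3-yl on an aromatic carbon. The thiophen-3-yl leaves and a furan-3-yl enters, on an aromatic carbon of the shared core, meta to two pyridin-2-yl groups and opposite the ring nitrogen. For the measured compounds named here, none of the measured steps touches this five-membered ring; the step from compound 1 to compound 3 alters a pyridin-2-yl and gives no guide to a thiophen-3-yl-to-furan-3-yl exchange. With nothing measured to size it, the account expects for compound 4 a step of a 1.6-fold higher number from compound 1 to compound 4 (0.21 log units; within the scatter), close to the scatter and, if anything, a slightly higher number. Compound 4 is therefore estimated at 1 ug/mL, with a range from 0.3 ug/mL to 4 ug/mL.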

Compound 4, concentration for 50% growth inhibition: 0.08 ug/mL
For compound 4 the middle estimate is 13-fold (1.10 log units) above the measured one, and the stated range ends above it.
By their numbers in this assay, from the lowest: compound 4; then compound 1; then compound 2. At a limit, above all of these: compound 3.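

The exchange gives a 7.8-fold lower number from compound 1 to compound 4 (0.89 log units; beyond the scatter) in this assay, so this aromatic carbon opposite the ring nitrogen is not indifferent to which five-membered ring it carries. The two groups match in heavy atoms, hydrogen-bond donors and acceptors and differ in that sulfur gives way to oxygen in the ring, yet that alone moves the number towards stronger inhibition of growth, the opposite direction to the earlier single step, which altered a pyridin-2-yl group. The material shown offers no measurement that explains why the furan-3-yl group does better here than the thiophen-3-yl group.

As far as these compounds go, what stays open is how far this position tolerates other groups, such as a phenyl ring, a furan-2-yl ring, a simple amine or a carboxylic acid, and whether any of them keeps the number as low as the furan-3-yl group does. From the compounds shown here alone, it is also open whether the gain from furan-3-yl would carry over to a compound with pyridin-3-yl in place of pyridin-2-yl, or holds only alongside the two pyridin-2-yl groups of compound 4.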